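A few compounds are considered here, and "the series" means these few. Any claim that something is new, unique, unknown or untested is made for them only; others in the source may bear on it.

Of the compounds shown here, two have been measured so far. Compound 1 `NS(=O)(=O)c1ccc(NC(=O)c2ccc(F)cc2)cc1` gives 5910 nM in an assay on isolated protein for inhibition of Intestinal-type alkaline phosphatase (Bos taurus), read by chemiluminescence and spectrophotometry; on this read-out lower numbers stand for stronger inhibition and higher numbers for weaker inhibition. Compound 2 `Cc1ccc(S(=O)(=O)Nc2ccc(S(N)(=O)=O)cc2)cc1` gives 14500 nM in this assay, which is the higher of the two numbers and so the weaker inhibition; its value stands beyond the usual scatter from that of compound 1. Compound 3 `CCOc1ccc(NS(=O)(=O)c2ccc(C)cc2)cc1` has not been measured. It differs from compound 2 in one place: ethoxy in place of sulfamoyl on an aromatic carbon, so that the group carrying the donor and two acceptors is exchanged for a shorter group with a single acceptor. Among the measured compounds shown here, no measured pair shows such a step, so its size is unknown from the data. The expectation is a step from compound 2 to compound 3 of a 2.8-fold higher number from compound 2 to compound 3 (0.44 log units; beyond the scatter) toward weaker inhibition, beyond the scatter. Compound 3 is accordingly expected to give about 40000 nM in this assay, within a range from 10000 nM to 150000 nM.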

Compound 3, half-maximal inhibitory concentration: 30100 nM
Compound 3: middle estimate off by 1.3-fold (0.12 log units), on the high side; measured number inside the range.
By their numbers in this assay, from the lowest: compound 1; then compound 2; then compound 3.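

In this assay, ethoxy in place of sulfamoyl on an aromatic carbon, para to a large group, gives a 2.1-fold higher number from compound 2 to compound 3 (0.32 log units; beyond the scatter) toward weaker inhibition, a modest step but one beyond the usual scatter. Among the compounds shown here, this is the first single-place change measured, and it shows that the number rises when sulfamoyl, with its hydrogen-bond donor and two acceptors, gives way to ethoxy, yet compound 3 still gives a measurable half-maximal value. Nothing measured here explains this step.

The compounds shown leave open how an amine, a carboxylic acid or a longer alkoxy chain would read at this place, and so which part of the sulfamoyl group matters. They also leave open whether the same exchange made on compound 1 would give a step of similar size.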